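A few compounds are considered here, and "the series" means these few. Any claim that something is new, unique, unknown or untested is made for them only; others in the source may bear on it.

Four compounds share one core and differ only on a six-membered aromatic ring of carbon only. Compound 1 is `CC/C(=C(/c1ccc(/C=C/C(=O)O)cc1)c1cc2ccccc2[nH]1)c1ccccc1C#N`, compound 2 is `CC/C(=C(/c1ccc(/C=C/C(=O)O)cc1)c1cc2ccccc2[nH]1)c1ccccc1C(F)(F)F`, compound 3 is `CC/C(=C(/c1ccc(/C=C/C(=O)O)cc1)c1cc2ccccc2[nH]1)c1ccc(Cl)cc1C#N`, and compound 4, not yet measured, is `CC/C(=C(/c1ccc(/C=C/C(=O)O)cc1)c1cc2ccccc2[nH]1)c1ccc(Cl)cc1C(F)(F)F`.

In a functional assay on MCF7 cells (Homo sapiens) for inhibition (a lower number here means a stronger inhibitor, a higher number a weaker inhibitor), compound 1 gives 9 nM. Compound 2 gives 8 nM in this assay, and compound 3 gives 14 nM in this assay. The change from compound 1 to compound 2 is trifluoromethyl in place of cyano on an aromatic carbon, and the step it made was a 1.1-fold lower number from compound 1 to compound 2 (0.05 log units; within the scatter). The cores of compound 1 and compound 3 differ by chloro in place of hydrogen on an aromatic carbon.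

The change from compound 3 to compound 4 is trifluoromethyl in place of cyano on an aromatic carbon. Among the measured compounds shown here, it is the same kind of change as the one from compound 1 to compound 2, but around the place there is a difference: in compound 3 the ring carbon is also meta to a chloro group, which the earlier pair lacks. For the measured compounds named here, only one example of this change has been measured, so the expectation rests on a single step. Because a 1.1-fold lower number from compound 1 to compound 2 (0.05 log units; within the scatter) lay within the scatter, the step expected from compound 3 to compound 4 in this assay is a 1.1-fold lower number from compound 3 to compound 4 (0.03 log units; within the scatter), nearly flat. For compound 4 the estimated value in this assay is 13 nM, expected to fall between 6 nM and 28 nM.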

Compound 4, half-maximal inhibitory concentration: 4 nM
Beside the measured number, compound 4's estimate is 3.3-fold (0.51 log units) above it; measured number below the stated range.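

In this assay, among the compounds shown here, the swap of cyano for trifluoromethyl does not carry over unchanged from one core to the other: with the chloro group present it gives a 3.5-fold lower number from compound 3 to compound 4 (0.54 log units; beyond the scatter), whereas the core without chloro shows almost no step, and the two steps differ: the same change on two cores in this assay, a 1.1-fold lower number (0.05 log units; within the scatter) from compound 1 to compound 2 and a 3.5-fold lower number (0.54 log units; beyond the scatter) from compound 3 to compound 4, 3.1-fold (0.49 log units) apart, beyond the scatter of two such steps. Read the other way, adding chloro to the trifluoromethyl compound gives a 2.0-fold lower number from compound 2 to compound 4 (0.30 log units; within the scatter), which lies within the scatter, yet this step still differs from the one for adding chloro to the cyano compound: the same change on two cores in this assay, a 1.6-fold higher number (0.19 log units; within the scatter) from compound 1 to compound 3 and a 2.0-fold lower number (0.30 log units; within the scatter) from compound 2 to compound 4, 3.1-fold (0.49 log units) apart, beyond the scatter of two such steps. Making both changes at once gives a 2.3-fold lower number from compound 1 to compound 4 (0.35 log units; beyond the scatter), so in these four compounds the size of each step depends on the other group present, but this rests on a single square of compounds, with one step per core, and it does not show why the steps differ or whether the same would hold on any other core.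

As far as these compounds go, it remains open whether trifluoromethyl would give a similar step over cyano with a fluoro, bromo or methoxy group in place of the chloro group. From the compounds shown here alone, it is also open whether a methyl group in place of the trifluoromethyl or cyano group would follow either core's behaviour.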